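Swapping thiophen-2-yl for benzofuran-2-yl at a dead end

The source may report more compounds than this note shows. Statements on the series, on what has been measured and on what is new or still open speak of the compounds shown alone.

Compound 1 `Cc1ncnc2c1c(-c1cc3ccccc3o1)cn2[C@@H]1O[C@H](CO)[C@@H](O)[C@H]1O`, compound 2 `Cc1ncnc2c1c(-c1cccs1)cn2[C@@H]1O[C@H](CO)[C@@H](O)[C@H]1O` and compound 3 `CN(C)c1ncnc2c1c(-c1cccs1)cn2[C@@H]1O[C@H](CO)[C@@H](O)[C@H]1O` share one core. In a functional assay on HeLa S3 cells (Homo sapiens) for antiproliferative activity, read by XTT assay, with a stated time of 72 h (a higher number here means a weaker inhibitor, a lower number a stronger inhibitor), compound 2 reaches only a limit, > 15000 nM. Compound 1 likewise gives only a limit in this assay, > 20000 nM. Compound 3 too stops at a limit in this assay, > 20000 nM. Compound 1 differs from compound 2 by 1-benzofuran-2-yl in place of thiophen-2-yl on an aromatic carbon, and the step that the two limits leave unreadable from compound 2 to compound 1 cannot be sized, as both values are limits. Compound 3 differs from compound 2 by dimethylamino in place of methyl on an aromatic carbon, and a step that the two limits leave unreadable from compound 2 to compound 3 is equally unreadable; the limit of > 15000 nM in this assay, at which 1 of the 3 values shown sits, and the limit of > 20000 nM in this assay, at which 2 of the 3 values shown sit, hold all three values. Compound 4 `CN(C)c1ncnc2c1c(-c1cc3ccccc3o1)cn2[C@@H]1O[C@H](CO)[C@@H](O)[C@H]1O` is not yet measured; it differs from compound 3 by 1-benzofuran-2-yl in place of thiophen-2-yl on an aromatic carbon, the same change as from compound 2 to compound 1. That change left compound 1 at a limit. Compound 4 is therefore expected to remain inactive, around 30000 nM in this assay. The expected step that the limit leaves unreadable from compound 3 to compound 4 rests on compound 1 showing no gain.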

Compound 4, half-maximal inhibitory concentration: > 20000 nM
Compound 4 ended at the assay's limit; the forecaster's own chance of this, stated with the estimate: 85%; the middle value does not contradict the limit.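

Compound 4 also stops at a limit in this assay, > 20000 nM, so the steps to it from compound 3 and from compound 1 cannot be read. The compounds shown leave open what either change does where a value is more than a limit.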